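Hydroxy in Place of Hydrogen: Cytotoxicity of Compound 3

A few compounds are considered here, and "the series" means these few. Any claim that something is new, unique, unknown or untested is made for them only; others in the source may bear on it.

Measured so far:
compound 1 `O=C(N/N=C/c1ccccc1)c1cccnc1`: 100 ug/mL
compound 2 `O=C(N/N=C/c1ccc(Cl)cc1)c1cccnc1`: > 100 ug/mL

For the measured compounds named here, in an ADME assay on HeLa cells (Homo sapiens) for cytotoxicity, read by microscopy (a lower number here means that less compound is tolerated, a higher number that more compound is tolerated), compound 1 gives 100 ug/mL, the only outright number among the two compounds tested. Compound 2 reaches only the limit of the assay, > 100 ug/mL, and is not a number. Going by the values given here, the one measured step, a number no lower from compound 1 to compound 2 (the limit leaves the size open), rests on that limit, (the limit of > 100 ug/mL in this assay, at which 1 of the 2 values shown sits), so its size stays open.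

Compound 3 `O=C(N/N=C/c1ccccc1O)c1cccnc1` is not yet measured. It differs from compound 1 in one place: hydroxy in place of hydrogen on an aromatic carbon. Among the compounds with values here, no measured step changes the same position in the same way; the step from compound 1 to compound 2 is the only guide, and it shows no drop. The expected step of no change at the digits printed from compound 1 to compound 3 (within the scatter) is therefore nothing beyond the scatter, since the measured step of a number no lower from compound 1 to compound 2 (the limit leaves the size open) gave no lower number. Compound 3 is expected to give 100 ug/mL, between 50 ug/mL and 200 ug/mL.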

Compound 3, minimum cytotoxic concentration: 4 ug/mL
Compound 3: the middle estimate sits 25-fold (1.40 log units) above what was measured; measured number outside the range, below it.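

In this assay, hydroxy in place of hydrogen on an aromatic carbon, ortho to a large group, gives a 25-fold lower number from compound 1 to compound 3 (1.40 log units; beyond the scatter), so a single added oxygen at this position is enough to move the number well beyond the scatter. Compound 2 showed no such fall, but it stands at a limit, so the size of its step cannot be read: the limit of > 100 ug/mL in this assay, at which 1 of the 3 values shown sits. Nothing measured here says why hydroxy has this effect.

On these data alone, it remains open whether the fall belongs to hydroxy alone or would also follow with a methoxy group or an amine on the same carbon. As far as these compounds go, it is equally open whether hydroxy on a different aromatic carbon of this ring would give a similar number.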